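The compounds below may be only part of what the source reports. "The series", "measured", "known", "first", "only" and "open" are said of these compounds alone.

Of the compounds shown here, three have so far been measured in a functional assay on the whole organism for inhibition, with Rattus norvegicus as the target, read by paw edema, at a dose of 100 mg/kg by the oral route; on this read-out higher numbers stand for more inhibition at the one dose given (going by the name of the read-out) and lower numbers for less inhibition.

Compound 1 `O=C(NN1CCOCC1)c1c(O)c2cccnc2n(-c2ccccc2)c1=O` gives -8.5%.
Compound 2 `COc1ccc(NC(=O)c2c(O)c3cccnc3n(-c3ccccc3)c2=O)cc1` gives 0.3%.
Compound 3 `COc1cccc(NC(=O)c2c(O)c3cccnc3n(-c3ccccc3)c2=O)c1` gives 5.7%.

Compound 3 has the highest number of the three, but the margins differ. Its nearest neighbour is compound 2: the step of a number 5.4 percentage points higher from compound 2 to compound 3 (within the scatter), so the two cannot be told apart. Its furthest neighbour is compound 1: the step of a number 14.2 percentage points higher from compound 1 to compound 3 (beyond the scatter). Between compound 1 and compound 2 the step of a number 8.8 percentage points higher from compound 1 to compound 2 (within the scatter).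

Compound 4 `O=C(Nc1ccncc1)c1c(O)c2cccnc2n(-c2ccccc2)c1=O` has not been measured. The change from compound 3 is pyridin-4-yl in place of 3-methoxyphenyl on an amide-type nitrogen. Among the measured compounds shown here, all three measured steps touched the same amide-type nitrogen, yet none of them swapped an aromatic ring of carbon only for a ring with a hetero atom, so there is no direct precedent. What the measured steps do show is that changes at this position moved the number only modestly at most, and two of them stayed within the scatter. The expectation for compound 4 is therefore no step beyond the scatter, with the step of a number 3.7 percentage points lower from compound 3 to compound 4 (within the scatter) estimated as a small drift downward. In this assay compound 4 is estimated to give 2%, within a range from -10% to 14%.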

Compound 4, a percentage reported as inhibition, in the whole organism at one dose (the size of the read-out at that dose, not a potency): 34.9%
Beside the measured number, compound 4's estimate is 32.9 percentage points below it; measured number above the stated range.
By their numbers in this assay, from the lowest: compounds 1, 2 and 3 (each within the scatter of the next, the first and the last beyond it); then compound 4.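

Among the compounds shown here, at this amide-type nitrogen in this assay, the kind of aromatic ring matters far more than the earlier compounds suggested: with pyridin-4-yl in place of 3-methoxyphenyl, the result is a number 29.2 percentage points higher from compound 3 to compound 4 (beyond the scatter). Compound 4 also clears the other two compounds, with a number 34.6 percentage points higher from compound 2 to compound 4 (beyond the scatter) and a number 43.4 percentage points higher from compound 1 to compound 4 (beyond the scatter), so it stands apart from all three, whereas moving the methoxy group around the phenyl ring had produced no change that could be told from the scatter. Nothing available here explains why this swap has such an effect.

The swap also makes two changes at once, as the methoxy group leaves and the carbon-only ring gives way to a ring containing nitrogen, so the compounds shown cannot say which change counts, and a plain phenyl on the same nitrogen would help separate them. Pyridin-3-yl or pyridin-2-yl would then show whether the place of the ring nitrogen matters, while a pyrimidine ring would show whether a second ring nitrogen adds anything further.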